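Thiourea in place of cyanoguanidine on the phenylpyridazinone chain

A few compounds are considered here, and "the series" means these few. Any claim that something is new, unique, unknown or untested is made for them only; others in the source may bear on it.

Within the data shown here, compound 2 `CN(C)/C(=N/CCCn1nc(-c2ccccc2)ccc1=O)NC#N` gives 53 mg/kg in a functional assay on the whole organism (stomach) with Rattus norvegicus as the target (a lower number here means that less compound is needed, a higher number that more compound is needed for the effect), and is the only compound of the pair with a number. Compound 1 `N#CNC(=N)NCCCn1nc(-c2ccccc2)ccc1=O` reaches only a limit of the assay in this assay, > 100 mg/kg. The step of an at least 1.8-fold lower number from compound 1 to compound 2 (0.27 log units; that floor lies within the scatter) rests on that limit (the limit of > 100 mg/kg in this assay, at which 1 of the 2 values shown sits). Compound 3 `CC/N=C(\S)NCCCCn1nc(-c2ccccc2)ccc1=O` differs from compound 2 by a group of 7 heavy atoms (4 carbon, 2 nitrogen, 1 sulfur; no ring) in place of a group of 8 heavy atoms (4 carbon, 4 nitrogen; no ring), on a saturated chain carbon, three bonds along the chain from an aromatic nitrogen. Among the measured compounds shown here, no measured step covers this change, and the one step known lies within the scatter. For compound 3 a step of about a 1.1-fold lower number from compound 2 to compound 3 (0.03 log units; within the scatter) is expected. Compound 3 is estimated at 50 mg/kg, with a range of 20 mg/kg to 150 mg/kg.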

Compound 3, dose for half-maximal effect: 37.2 mg/kg
For compound 3 the middle estimate is 1.3-fold (0.13 log units) above the measured one; low and high end bracket the measured number.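

In this assay, the sulfur-bearing group takes the place of the cyanoguanidine group of compound 2 with no difference that can be read: a 1.4-fold lower number from compound 2 to compound 3 (0.15 log units; within the scatter). Against compound 1, the same group gives the first gap beyond the scatter: an at least 2.6-fold lower number from compound 1 to compound 3 (0.42 log units; beyond the scatter). Compound 1 stands only at a limit of the assay, so this step is a floor and not a measured size: the limit of > 100 mg/kg in this assay, at which 1 of the 3 values shown sits.

Going by these compounds, how a urea or a plain amine would read at this place stays open. So does which part of the sulfur-bearing group separates compound 3 from compound 1.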